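Dimethylamino to diethylamino at two chain lengths

The source may hold more compounds than are shown below. What is called first, only, known or untested is meant among the compounds shown, and "the series" means these compounds.

Compound 1 `CN(C)CCn1c(N)c(-c2nc3ccccc3[nH]2)c2nc(C#N)c(C#N)nc21` gives 2220 nM in a functional assay on HL-60 cells (Homo sapiens) for antiproliferative activity, read by MTT assay, with a stated time of 48 h; on this read-out lower numbers stand for stronger inhibition and higher numbers for weaker inhibition. Compound 2 `CCN(CC)CCn1c(N)c(-c2nc3ccccc3[nH]2)c2nc(C#N)c(C#N)nc21` carries the change diethylamino in place of dimethylamino on a saturated chain carbon, two bonds along the chain from an aromatic nitrogen and gives 1880 nM in this assay; the step is a 1.2-fold lower number from compound 1 to compound 2 (0.07 log units; within the scatter). Compound 3 `CN(C)CCCn1c(N)c(-c2nc3cc(Cl)ccc3[nH]2)c2nc(C#N)c(C#N)nc21` gives 2930 nM in this assay; the difference between its core and the core of compound 1 is not broken down here. Compound 4 `CCN(CC)CCCn1c(N)c(-c2nc3cc(Cl)ccc3[nH]2)c2nc(C#N)c(C#N)nc21` is not yet measured. It differs from compound 3 by diethylamino in place of dimethylamino on a saturated chain carbon, three bonds along the chain from an aromatic nitrogen; this is the same kind of change as that from compound 1 to compound 2, but the place differs: there the group sits two bonds along the chain from an aromatic nitrogen, here three bonds along the chain from an aromatic nitrogen. Because the earlier step of a 1.2-fold lower number from compound 1 to compound 2 (0.07 log units; within the scatter) stayed within the scatter, the expected step is a 1.2-fold lower number from compound 3 to compound 4 (0.07 log units; within the scatter). The estimate for compound 4 is 2500 nM, between 1200 nM and 5200 nM.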

Compound 4, half-maximal inhibitory concentration: 3470 nM
Compound 4: middle estimate off by 1.4-fold (0.14 log units), on the low side, and the stated range covers the measured number.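

In this assay, diethylamino in place of dimethylamino on the propyl chain gives a 1.2-fold higher number from compound 3 to compound 4 (0.07 log units; within the scatter). The swap therefore carries from one core to the other as a step too small to read on either, and the two steps do not differ: the same change on two cores in this assay, a 1.2-fold lower number (0.07 log units; within the scatter) from compound 1 to compound 2 and a 1.2-fold higher number (0.07 log units; within the scatter) from compound 3 to compound 4, 1.4-fold (0.15 log units) apart, within the scatter of two such steps. This does not show a real direction for the change on either core, and two pairs within the scatter cannot establish that the same holds across the series or separate any influence of chain length from that of the rest of the core.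

Still open, going by these compounds, is whether a larger change at the chain end, such as dipropylamino or a primary amine, would give a readable step. On these data alone, a longer chain carrying the same amines also remains open.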